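This account rests on a few compounds, and the source may have more. Where it says the series, first, only, none or still open, it means among the compounds named here.

Compound 1 `O=C(O)c1ccccc1-c1ccc(CCc2ncc(CCC3CCCCC3)[nH]2)cc1`: 642 nM
Compound 2 `CCCCc1cnc(C(CCCC)Cc2ccc(-c3ccccc3C(=O)O)cc2)[nH]1`: 2660 nM
Compound 3 `O=C(O)c1ccccc1-c1ccc(CCc2ncc(-c3ccccc3)[nH]2)cc1`: 4950 nM

In an in vitro functional assay on cells for agonist activity at Bombesin receptor subtype-3 (Homo sapiens), read by luminescence and calcium flux (a lower number here means that less compound is needed, a higher number that more compound is needed for the effect), compound 3 stands at the highest of the three numbers; compound 2 sits within the scatter of it, whereas the one step shown that goes beyond the scatter is a 7.7-fold higher number from compound 1 to compound 3 (0.89 log units; beyond the scatter), where phenyl replaced 2-cyclohexylethyl. Compound 4 `Cc1ccc(Cc2cnc(CCc3ccc(-c4ccccc4C(=O)O)cc3)[nH]2)cc1` carries the change (4-methylbenzyl in place of phenyl on an aromatic carbon). Among the compounds with values here, only that step bears on it, and it suggests that a larger group on this aromatic carbon accompanies a lower number. The account therefore expects compound 4 to give a number below that of compound 3, by a 3.3-fold lower number from compound 3 to compound 4 (0.52 log units; beyond the scatter), a step likely beyond the scatter but short of the whole gap to compound 1. The estimate for compound 4 is 1500 nM, within 500 nM to 4500 nM.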

Compound 4, half-maximal effective concentration: 2660 nM
Estimate against measurement, compound 4: 1.8-fold (0.25 log units) below, within the range that was stated.
By their numbers in this assay, from the lowest: compound 1; then compounds 2, 4 and 3 (each within the scatter of the next).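

Placing 4-methylbenzyl on this aromatic carbon instead of phenyl leaves the number within the scatter (a 1.9-fold lower number from compound 3 to compound 4 (0.27 log units; within the scatter)), so going from 6 to 8 heavy atoms with one aromatic ring retained does not separate these two compounds. The 2-cyclohexylethyl group remains clearly ahead of 4-methylbenzyl at this position (a 4.1-fold higher number from compound 1 to compound 4 (0.62 log units; beyond the scatter)). No measurement offered here explains either step.

On these data alone, whether the lower number of compound 1 follows its saturated ring or its chain remains open, as does the effect of an amine at the end of a longer chain on this carbon.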